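The compounds below may be only part of what the source reports. "The series", "measured", "known", "first", "only" and "open" are said of these compounds alone.

Measured compounds:
- Compound 1 `CCC(COC(=O)NCc1ccccc1)Oc1cccc(C(F)(F)F)c1`; in an assay for inhibition of zeta-carotene desaturase, chloroplastic/chromoplastic (Capsicum annuum), using a Dixon plot, with a stated time of 8 h (a lower number here means a stronger inhibitor, a higher number a weaker inhibitor), compound 1 gives > 100000 nM, which is a limit of the assay and not a number.
- Compound 2 `O=C(NCc1ccccc1)OCCOc1cccc(C(F)(F)F)c1`; in this assay compound 2 gives > 100000 nM, again a limit of the assay.

Among the compounds with values here, compound 2 therefore stands at the limit, with no numerical value of its own; the single further value, that of compound 1, is also a limit. Within the data shown here, the one step between measured compounds, a step that the two limits leave unreadable from compound 1 to compound 2, cannot be read in size or direction because both ends sit at the limit of > 100000 nM in this assay, at which 2 of the 2 values shown sit.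

The next compound, compound 3 `O=C(NCc1ccccc1)OC(CCl)COc1cccc(C(F)(F)F)c1`, differs from compound 2 by chloromethyl in place of hydrogen on a saturated chain carbon bound to an oxygen next to a carbonyl group and a saturated chain carbon. Among the measured compounds shown here, no measured step bears on this change, and the only step that exists is unreadable, so no direction of effect can be drawn from the data. Compound 3 is expected most likely to remain at the limit as well; the estimate for compound 3 in this assay is 150000 nM, with a range from 40000 nM to 600000 nM. The implied step that the limit leaves unreadable from compound 2 to compound 3 is thus expected to be none beyond the scatter, with a limit the probable outcome.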

Compound 3, half-maximal inhibitory concentration: > 100000 nM
Compound 3: no number, only a limit; the forecaster's own chance of this, stated with the estimate: 85%; the middle value does not contradict the limit.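

In this assay compound 3 gives > 100000 nM, a limit of the assay and not a number, so the step between compound 2 and compound 3 cannot be read in size or direction. The compounds shown leave open which change to the shared core, if any, would give a measurable value: the limit of > 100000 nM in this assay, at which 3 of the 3 values shown sit.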